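Terminal amine substitution, compound 2 to compound 3

This account rests on a few compounds, and the source may have more. Where it says the series, first, only, none or still open, it means among the compounds named here.

Compound 2 `CC(C)(CN)CCN(C[C@H]1Cc2ccccc2CN1)[C@H]1CCCc2cccnc21` was run in a functional assay on cells for agonist activity at C-X-C chemokine receptor type 4 (Homo sapiens), read by fluorescence and calcium flux, with a stated time of 90 s; a higher number here means that more compound is needed for the effect, a lower number that less compound is needed. In this assay compound 2 gives only a limit, > 30000 nM. Compound 1 `O=S1(=O)CCC(CNCCCCN(C[C@H]2Cc3ccccc3CN2)[C@H]2CCCc3cccnc32)CC1` also gives only a limit in this assay, > 30000 nM. The step that the two limits leave unreadable from compound 1 to compound 2 is therefore unreadable, both values sitting at the limit of > 30000 nM in this assay, at which 2 of the 2 values shown sit. Compound 3 `CC1(C)CCC(NCC(C)(C)CCN(C[C@H]2Cc3ccccc3CN2)[C@H]2CCCc3cccnc32)CC1` carries 4,4-dimethylcyclohexyl in place of hydrogen on an amine nitrogen. Among the compounds with values here, no measured step bears on this change, so the series sets no direction for it. The step from compound 2 to compound 3 is expected to be a number no higher from compound 2 to compound 3 (the limit leaves the size open). For compound 3 the expected value is 30000 nM, with the expected range from 3000 nM to 100000 nM.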

Compound 3, half-maximal effective concentration: > 30000 nM
Compound 3 ended at the assay's limit; the forecaster's own chance of this, stated with the estimate: 70%; the middle value sits exactly at the limit.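

Compound 2 and compound 3 each give only a limit in this assay, so the step between them cannot be read. The compounds shown leave open what 4,4-dimethylcyclohexyl on the amine nitrogen does to the read-out.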